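Aryloxyalkyl series: cytotoxicity expectation for compound 4

The source may hold more compounds than are shown below. What is called first, only, known or untested is meant among the compounds shown, and "the series" means these compounds.

Compound 3 `O=C1N(CCCCCCOc2cccc(Br)c2)CCN1c1ccncc1` gives only a limit in a functional assay on cells (Homo sapiens) for cytotoxicity; a higher number here means that more compound is tolerated, a lower number that less compound is tolerated: its value of > 25000 nM marks the edge of the assay and is not a number. Compound 1 `O=C1N(CCCCCCCOc2ccc(Br)cc2)CCN1c1ccncc1` likewise reaches only a limit, > 25000 nM. Compound 2 `O=C1N(CCCCCCCOc2ccc(Cl)cc2)CCN1c1ccncc1` also returns a limit, > 25000 nM. Every value in the set sits at the limit of > 25000 nM in this assay, at which 3 of the 3 values shown sit, so none of the steps among the measured compounds can be sized: a step that the two limits leave unreadable from compound 1 to compound 2, a step that the two limits leave unreadable from compound 1 to compound 3 and a step that the two limits leave unreadable from compound 2 to compound 3 are all unreadable.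

Compound 4 `COc1ccc(OCCCCCCN2CCN(c3ccncc3)C2=O)c(Cl)c1` differs from compound 3 by 2-chloro-4-methoxyphenyl in place of 3-bromophenyl on an oxygen on a saturated carbon. Going by the values given here, no measured step swaps one aryloxy group for another while adding a methoxy group, so none bears directly on this change; the only guidance is that each aryloxy variant measured so far, whether bromo or chloro and at either chain length, stayed at the limit. The estimated step that the limit leaves unreadable from compound 3 to compound 4 therefore expresses the expectation that compound 4 also sits at the limit rather than any movement beyond the scatter. Compound 4 is expected to give about 30000 nM in this assay, within 20000 nM to 60000 nM, and most probably reported again only as a limit.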

Compound 4, half-maximal cytotoxic concentration: > 25000 nM
Compound 4 gave a limit, no number; the forecaster's own chance of this, stated with the estimate: 85%; the middle value is on the limit's open side.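

Going by these compounds alone, compound 4 in this assay gives > 25000 nM, which is a limit and not a number; compound 3 is also a limit, so no step between compound 3 and compound 4 can be read. All values shown sit at one edge: the limit of > 25000 nM in this assay, at which 4 of the 4 values shown sit. The compounds shown leave open whether any aryloxy variant reaches a measurable cytotoxic concentration.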